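Three compounds at a limit and a fourth awaited

A few compounds are considered here, and "the series" means these few. Any claim that something is new, unique, unknown or untested is made for them only; others in the source may bear on it.

In a functional assay on Huh-7 cells (Homo sapiens) for cytotoxicity, read by WST assay, with a stated time of 72 h (a lower number here means a stronger inhibitor, a higher number a weaker inhibitor), compound 1 `CC1=CC(=O)C[C@H](C)[C@@]1(C)CC/C(C)=C/CC/C(C)=C/C[n+]1cn(C)c2ncnc(N)c21` gives > 50000 nM as a limit of the assay and not a number. Compound 2 `CC1=CCC[C@H](C)[C@@]1(C)CCC(C)(O)CCC/C(C)=C/C[n+]1cn(C)c2ncnc(N)c21` gives > 50000 nM which is likewise a limit. Compound 3 `CC1=CCC[C@H]2[C@](C)(CC/C(C)=C/Cn3c[n+](C)c4ncnc(N)c43)[C@@H](C)CC[C@@]12C` gives > 50000 nM which is also only a limit. The measured set therefore shows the limit of > 50000 nM in this assay, at which 3 of the 3 values shown sit, and offers no exact value for comparison. Compound 4 `CC1=CCC[C@@H]2[C@@](C)(CC/C(C)=C/Cn3c[n+](C)c4ncnc(N)c43)[C@H](C)CC[C@@]12C` is still unmeasured, and its change from compound 3 is the two compounds have the same atoms and bonds and differ only in configuration as drawn: 3 of 5 stereo elements differ; a stereocentre at a saturated ring carbon is drawn S in compound 3 and R in compound 4; a stereocentre at a saturated ring carbon is drawn R in compound 3 and S in compound 4; a stereocentre at a saturated ring carbon is drawn S in compound 3 and R in compound 4 with the same atoms and bonds throughout. With compound 3 at > 50000 nM as a limit, no shift beyond the scatter is expected in this assay from this change. The expected step is a number no higher from compound 3 to compound 4 (the limit leaves the size open) and so stays small. The estimate for compound 4 is 50000 nM with an expected range from 25000 nM to 100000 nM and a good chance of another limit.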

Compound 4, half-maximal inhibitory concentration: 22000 nM
The estimate for compound 4 lay 2.3-fold (0.36 log units) above the measured number, and the stated range ends above it.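

In this assay, among these compounds, the result gives the first step that can be read in this set (an at least 2.2-fold lower number from compound 3 to compound 4 (0.35 log units; beyond the scatter)). Configuration alone is enough to move the number beyond the scatter, as no atom or bond changes: (the fact that compounds 3 and 4 differ only in the configuration as drawn). Even so, most of the set remains at a limit: (the limit of > 50000 nM in this assay, at which 3 of the 4 values shown sit).

From the compounds shown here alone, the three stereocentres change together, so the share of each remains open. Going by these compounds, it is also open how compound 4 would respond to an added group, such as an amine or a carboxylic acid, on the shared core.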